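Swapping the benzyl halogen on a triazole-linked chalcone

The source may hold more compounds than are shown below. What is called first, only, known or untested is meant among the compounds shown, and "the series" means these compounds.

Compound 3 `COc1ccc(C(=O)/C=C/c2ccc(OCc3cn(Cc4cccc(Br)c4)nn3)cc2)cc1` gives 27% in a functional assay on HepG2 cells (Homo sapiens) for inhibition, read by MTT assay, with a stated time of 48 h, tested at 10 uM (a lower number here means less inhibition of growth, a higher number more inhibition of growth at the concentration tested), the lowest of the three numbers measured. Compound 1 `O=C(/C=C/c1ccc(OCc2cn(Cc3ccccc3F)nn2)cc1)c1ccc(Br)cc1` gives 29% in this assay, which lies within the scatter of compound 3. Among the measured compounds shown here, compound 2 `COc1ccc(C(=O)/C=C/c2ccc(OCc3cn(Cc4ccccc4)nn3)cc2)cc1` gives 51%, and the only single-point step among the measured compounds runs a number 24 percentage points lower from compound 2 to compound 3 (beyond the scatter). Compound 4 `COc1ccc(C(=O)/C=C/c2ccc(OCc3cn(Cc4ccccc4F)nn3)cc2)cc1` differs from compound 3 by 2-fluorophenyl in place of 3-bromophenyl on a saturated chain carbon bound to an aromatic nitrogen. For the measured compounds named here, no measured step bears directly on this exchange; compound 1, which carries the same 2-fluorobenzyl group but a different ketone aryl substituent, shows only what its own value shows, and the measured step from compound 2 to compound 3 tells that adding bromo to an unsubstituted benzyl lowered the number modestly. Removing that bromo and placing fluoro elsewhere on the ring is therefore expected to move the number back part of the way toward compound 2, as a number 11 percentage points higher from compound 3 to compound 4 (beyond the scatter), a step near the edge of the scatter. Compound 4 is expected to give 38%, estimated between 20% and 58%.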

Compound 4, percent growth inhibition at one concentration: 33%
Beside the measured number, compound 4's estimate is 5 percentage points above it; the measured number falls inside the stated range.
By their numbers in this assay, from the lowest: compounds 3, 1 and 4 (each within the scatter of the next); then compound 2.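

The fluoro step, a number 18 percentage points lower from compound 2 to compound 4 (beyond the scatter), shows that in this assay a second halogenated benzyl group also falls beyond the scatter from the unsubstituted benzyl of compound 2, so this is not seen with bromo alone. Exchanging the groups themselves leaves no readable difference, with 2-fluorophenyl in place of 3-bromophenyl giving a number 6 percentage points higher from compound 3 to compound 4 (within the scatter), and on the other side of the molecule methoxy in place of bromo gives a number 4 percentage points higher from compound 1 to compound 4 (within the scatter). Nothing shown gives a measured reason for these steps.

On these data alone, since halogen and ring position change together from compound 3 to compound 4, the effect of each alone stays open. Also open, as far as these compounds go, is how a benzyl ring carrying an amine or a carboxylic acid, or a longer chain in place of the benzyl group, would read in this assay.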